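Working notes: fluoro to trifluoromethyl in a small series

The compounds below may be only part of what the source reports. "The series", "measured", "known", "first", "only" and "open" are said of these compounds alone.

In an ADME assay on MT4 cells (Homo sapiens) for cytotoxicity, read by MTT assay, with a stated time of 4 days (on this read-out higher numbers stand for lower toxicity in this test and lower numbers for higher toxicity in this test), compound 1 `CC(=O)Nc1ccc2oc(-c3ccccc3)cc(=O)c2c1` gives 184000 nM, and compound 2 `CC(=O)Nc1ccc2oc(-c3ccc(F)cc3)cc(=O)c2c1` gives 203000 nM. These two values lie within the scatter of each other, so compound 2 holds no separate rank in this pair.

The next structure, compound 3 `CC(=O)Nc1ccc2oc(-c3ccc(C(F)(F)F)cc3)cc(=O)c2c1`, keeps the shared core and alters one substituent: trifluoromethyl in place of fluoro on an aromatic carbon. This is trifluoromethyl in place of fluoro on an aromatic carbon, para to a large group.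

Going by the values given here, only one measured step bears on this change: a 1.1-fold higher number from compound 1 to compound 2 (0.04 log units; within the scatter), for fluoro in place of hydrogen on an aromatic carbon. That step lies within the scatter. Among the compounds with values here, it is a single observation, and the series holds no measured compound carrying trifluoromethyl, so the basis for a prediction is thin. No step beyond the scatter is therefore expected in this assay, and no firm direction can be assigned.

The expected change is a 1.2-fold lower number from compound 2 to compound 3 (0.08 log units; within the scatter), an estimate that stays within the scatter. For compound 3 the estimated value is 170000 nM, with an expected range of 80000 nM to 300000 nM.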

Compound 3, half-maximal cytotoxic concentration: 330000 nM
Compound 3: the middle estimate sits 1.9-fold (0.29 log units) below what was measured; measured number above the stated range.
By their numbers in this assay, from the lowest: compounds 1, 2 and 3 (each within the scatter of the next).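

Trifluoromethyl brings 4 heavy atoms where fluoro has 1, yet on this aromatic carbon, para to a large group, the read-out in this assay shows a 1.6-fold higher number from compound 2 to compound 3 (0.21 log units; within the scatter). Set against the unsubstituted compound, the same group shows a 1.8-fold higher number from compound 1 to compound 3 (0.25 log units; within the scatter), so neither trifluoromethyl step leaves the scatter, and hydrogen, fluoro and trifluoromethyl at this place cannot be told apart in this test, a reading that earlier rested on the fluoro step alone. Nothing at hand bears on why the three values lie so close together.

As far as these compounds go, all three compounds carry hydrogen or fluorine-bearing groups at this place, with no hydrogen-bond donor or acceptor counted in the groups exchanged, so it remains open whether an amine, a carboxylic acid or a longer chain here would give a step beyond the scatter. From the compounds shown here alone, the acetamide of the shared core also stays the same throughout, and the effect on this read-out of exchanging it for a free amine or a longer acyl chain remains unknown.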